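A few compounds are considered here, and "the series" means these few. Any claim that something is new, unique, unknown or untested is made for them only; others in the source may bear on it.

Compound 1 `Oc1ccccc1-c1cc(-c2cccc(C(F)(F)F)c2)cc(-c2ccccc2O)n1` and compound 2 `Oc1ccccc1-c1cc(-c2ccc(C(F)(F)F)cc2)cc(-c2ccccc2O)n1` share a core bearing two 2-hydroxyphenyl groups. In a functional assay on DU-145 cells (Homo sapiens) for inhibition (a higher number here means a weaker inhibitor, a lower number a stronger inhibitor), compound 1 reaches only the limit of the assay, > 50000 nM. Compound 2 likewise reaches only the limit, > 50000 nM. The change between them, (4-(trifluoromethyl)phenyl in place of 3-(trifluoromethyl)phenyl on an aromatic carbon), gave a step that the two limits leave unreadable from compound 1 to compound 2, because of the limit of > 50000 nM in this assay, at which 3 of the 3 values shown sit. Compound 3 `Oc1cccc(-c2cc(-c3cccc(C(F)(F)F)c3)cc(-c3cccc(O)c3)n2)c1` carries 3-hydroxyphenyl groups instead; how its core differs from that of compound 1 is not broken down here. In this assay compound 3 also gives only the limit, > 50000 nM. Compound 4 `Oc1cccc(-c2cc(-c3ccc(C(F)(F)F)cc3)cc(-c3cccc(O)c3)n2)c1` is not yet measured. The change from compound 3 to compound 4, (4-(trifluoromethyl)phenyl in place of 3-(trifluoromethyl)phenyl on an aromatic carbon), is the same kind of change as that from compound 1 to compound 2, though here it sits meta to two 3-hydroxyphenyl groups rather than two 2-hydroxyphenyl groups. The step is expected to be a step that the limit leaves unreadable from compound 3 to compound 4, resting on compound 1 and compound 2 both sitting at the limit of > 50000 nM in this assay, at which 3 of the 3 values shown sit. Compound 4 is expected to give 80000 nM.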

Compound 4, half-maximal inhibitory concentration: 33500 nM
Compound 4: the middle estimate sits 2.4-fold (0.38 log units) above what was measured; the measured number falls inside the stated range.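

In this assay, 4-(trifluoromethyl)phenyl in place of 3-(trifluoromethyl)phenyl gives an at least 1.4-fold lower number from compound 3 to compound 4 (0.17 log units; that floor lies within the scatter) on the core bearing two 3-hydroxyphenyl groups. Compound 3 is only a limit, so this shows a measurable value for compound 4 but no readable gain beyond the scatter. The same change on the core of compound 1 cannot be read, so nothing shows whether the step carries from one core to the other, because both compounds on that core sit at the limit: the limit of > 50000 nM in this assay, at which 3 of the 4 values shown sit.

The compounds shown leave open what an amine or a carboxylic acid in place of the hydroxyl groups would do in this assay here. They also leave open whether a nitrile in place of trifluoromethyl would give a readable step on either core.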